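Notes on the aryl exchange at the amine nitrogen

A few compounds are considered here, and "the series" means these few. Any claim that something is new, unique, unknown or untested is made for them only; others in the source may bear on it.

Of the compounds shown here, two have been measured in a functional assay on MCF7 cells (Homo sapiens) for cytotoxicity, read by MTT assay, with a stated time of 24 h; a higher number here means a weaker inhibitor, a lower number a stronger inhibitor. Compound 1 `COc1cc2ncnc(Nc3cccc(C(F)(F)F)c3)c2cc1OCCCSc1nc2ccccc2s1` gives 4050 nM. Compound 2 `CCc1cc(Br)ccc1Nc1ncnc2cc(OC)c(OCCCSc3nc4ccccc4s3)cc12` gives 5870 nM. Among the measured compounds shown here, compound 2 stands at the top of the two numbers, but the gap to compound 1, the only step measured so far, a 1.4-fold higher number from compound 1 to compound 2 (0.16 log units; within the scatter), lies within the scatter, so the two compounds are not separable on these numbers.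

Compound 3 `COc1ccc(Nc2ncnc3cc(OC)c(OCCCSc4nc5ccccc5s4)cc23)cc1` is not yet measured. It differs from compound 2 by 4-methoxyphenyl in place of 4-bromo-2-ethylphenyl on a nitrogen on an aromatic ring. For the measured compounds named here, the single measured step bears on it only loosely: it also exchanged the aryl group on that nitrogen, and it came out as a 1.4-fold higher number from compound 1 to compound 2 (0.16 log units; within the scatter), within the scatter. Nothing in the series shows that a change at this position moves this assay beyond the scatter, so for compound 3 no step beyond the scatter is expected in either direction. The step from compound 2 to compound 3 is estimated at a 1.2-fold lower number from compound 2 to compound 3 (0.07 log units; within the scatter). Compound 3 is accordingly expected to give about 5000 nM in this assay, with a range from 2000 nM to 13000 nM.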

Compound 3, half-maximal inhibitory concentration: 14200 nM
Compound 3: middle estimate off by 2.8-fold (0.45 log units), on the low side, outside the stated range (above it).
By their numbers in this assay, from the lowest: compounds 1 and 2 (each within the scatter of the next); then compound 3.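

In this assay the aryl group on this nitrogen now proves able to move the number beyond the scatter, with a 2.4-fold higher number from compound 2 to compound 3 (0.38 log units; beyond the scatter) for the exchange of 4-bromo-2-ethylphenyl for 4-methoxyphenyl and a 3.5-fold higher number from compound 1 to compound 3 (0.54 log units; beyond the scatter) for the exchange of 3-(trifluoromethyl)phenyl for the same group. The position is therefore not indifferent to every aryl exchange: compound 1 and compound 2 remain within the scatter of each other despite their different aryl groups, and only compound 3, with 4-methoxyphenyl, stands apart, as the weakest of the three. No measurement at hand accounts for this separation.

The step from compound 2 to compound 3 changes several things at once, removing the bromine and the ethyl group and bringing in a methoxy group, so the compounds shown do not assign the shift to any one of these. From the compounds shown here alone, it also remains open whether a hydroxyl group or a dimethylamino group in place of the methoxy group on that phenyl ring would give a number near compound 3 or near compound 1 and compound 2.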